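The compounds below may be only part of what the source reports. "The series", "measured", "known", "first", "only" and "open" are said of these compounds alone.

Three compounds sharing one core were examined in an ADME assay on J774 cells (Mus musculus, strain BALB/c) for cytotoxicity, read by resazurin assay, with a stated time of 72 h; on this read-out lower numbers stand for higher toxicity in this test and higher numbers for lower toxicity in this test. Compound 1 `CC(/C=N/Nc1ccc([N+](=O)[O-])cc1)=N\NC(=O)c1ccccc1` is the unsubstituted parent; in this assay compound 1 reaches only the limit of the test, > 100000 nM. Compound 2 `CC(/C=N/Nc1ccc([N+](=O)[O-])cc1)=N\NC(=O)c1cccc(C)c1` carries a methyl on an aromatic carbon, and in this assay compound 2 is reported as a limit as well, > 100000 nM. Compound 3 `CC(/C=N/Nc1ccc([N+](=O)[O-])cc1)=N\NC(=O)c1ccc([N+](=O)[O-])cc1` carries a nitro on an aromatic carbon; in this assay compound 3 is given only as a limit, > 100000 nM. The steps a step that the two limits leave unreadable from compound 1 to compound 2, a step that the two limits leave unreadable from compound 1 to compound 3 and a step that the two limits leave unreadable from compound 2 to compound 3 cannot be sized, because every value shown sits at the limit of > 100000 nM in this assay, at which 3 of the 3 values shown sit. Compound 3 thus stands where all three compounds stand: at a limit, with no number of its own. Compound 4 `COc1ccc(C(=O)N/N=C(C)/C=N/Nc2ccc([N+](=O)[O-])cc2)cc1` differs from compound 3 by methoxy in place of nitro on an aromatic carbon. Within the data shown here, no measured step bears on this change with a readable size, since each of the three values is a limit. The step that the limit leaves unreadable from compound 3 to compound 4 is therefore expected to be none beyond the scatter. For compound 4 in this assay the estimated value is 150000 nM, within 60000 nM to 400000 nM.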

Compound 4, half-maximal cytotoxic concentration: > 100000 nM
Compound 4 gave a limit, no number (the forecaster's own chance of this, stated with the estimate: 85%); the middle value lies beyond the limit too.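

No step between compound 4 and compound 1, compound 2 or compound 3 can be read in this assay, because all the values shown stand at a single limit: the limit of > 100000 nM in this assay, at which 4 of the 4 values shown sit.

The compounds shown leave open whether any of these substituents on the shared core changes the half-maximal cytotoxic concentration at all.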